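The compounds below may be only part of what the source reports. "The series", "measured", "known", "first", "only" and "open" are said of these compounds alone.

Measured compounds and their values:

Compound 1 `CC(c1ccc(-c2ccccc2)c(F)c1)c1nnc2n1N=C(c1ccc(OC(F)(F)F)cc1)CS2`, 8400 nM
Compound 2 `COc1ccc2cc(C(C)c3nnc4n3N=C(c3ccc(C)cc3)CS4)ccc2c1`, 8200 nM
Compound 3 `COc1ccc(C2=Nn3c(nnc3C(C)c3ccc4cc(OC)ccc4c3)SC2)cc1`, 8500 nM

All three were tested in a functional assay on Huh-7 cells (Homo sapiens) for inhibition, read by sulforhodamine B assay, with a stated time of 72 h; on this read-out lower numbers stand for stronger inhibition and higher numbers for weaker inhibition. Compound 1 gives 8400 nM and sits second highest of the three numbers, but its nearest neighbour compound 3 gives 8500 nM and compound 2 gives 8200 nM, and all three values lie within the scatter of one another, so no order among them can be claimed.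

The unmeasured compound 4 `COc1ccc(C2=Nn3c(nnc3C(C)c3ccc(-c4ccccc4)c(F)c3)SC2)cc1` differs from compound 1 at a single spot: methyl in place of trifluoromethyl on an oxygen on an aromatic ring. Cut one bond further out, this reads as trifluoromethoxy to methoxy on the 4-substituted phenyl that hangs from the shared core.

Among the compounds with values here, only one measured step offers a comparison, and it is a loose one: the change from compound 2 to compound 3 swaps methyl for methoxy on an aromatic carbon of the same phenyl position and gives a 1.0-fold higher number from compound 2 to compound 3 (0.02 log units; within the scatter), a change within the scatter. Within the data shown here, no measured pair swaps trifluoromethyl for methyl on an oxygen, so the swap in question is untested here. Given that the one nearby step shows no movement, the expectation for this assay is a step from compound 1 to compound 4 of about a 1.0-fold higher number from compound 1 to compound 4 (0.01 log units; within the scatter), that is, nothing beyond the scatter.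

Compound 4 is therefore estimated at 8500 nM, with a range from 4000 nM to 18000 nM.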

Compound 4, half-maximal inhibitory concentration: 4300 nM
For compound 4 the middle estimate is 2.0-fold (0.30 log units) above the measured one; low and high end bracket the measured number.
By their numbers in this assay, from the lowest: compounds 4, 2, 1 and 3 (each within the scatter of the next).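

In this assay, within the data shown here, the exchange of trifluoromethyl for methyl on an oxygen on an aromatic ring, which turns 4-(trifluoromethoxy)phenyl into 4-methoxyphenyl, can now be read directly as a 2.0-fold lower number from compound 1 to compound 4 (0.29 log units; within the scatter), the first reading of this swap at this oxygen. Even with the fluorine atoms gone, the step stays within the scatter, so this pair gives no firm sign that the choice between the two groups matters here, and a single pair cannot settle whether a small real effect lies hidden inside that scatter. No measurement of any property of these groups is available to account for the reading.

The compounds shown carry only trifluoromethoxy, methoxy or methyl on this phenyl, so it remains open how a longer chain such as ethoxy, an amine or a carboxylic acid would read there. Also open, from the compounds shown here alone, is whether any change at this spot can give a step beyond the scatter, and whether the swap would read the same on a compound that differs elsewhere.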